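The compounds below may be only part of what the source reports. "The series", "measured", "known", "first", "only" and "open" are said of these compounds alone.

Among the measured compounds shown here, in a functional assay on KB cells (Homo sapiens) for inhibition, with a stated time of 72 h (a higher number here means a weaker inhibitor, a lower number a stronger inhibitor), two compounds sharing one core have numbers so far. Compound 1 (`COc1ccc(S(=O)(=O)N2CCc3cccc(-c4ccc([N+](=O)[O-])cc4)c32)cc1`) gives 52.5 nM and compound 2 (`COc1ccc(S(=O)(=O)N2CCc3cccc(-c4ccc(N(C)C)cc4)c32)cc1`) gives 539 nM as the higher of the two numbers, which makes compound 2 the weaker inhibitor of this pair. For the measured compounds named here, the only measured step is a 10-fold higher number from compound 1 to compound 2 (1.01 log units; beyond the scatter) and it is large, with dimethylamino in place of nitro on an aromatic carbon. Compound 3 (`COc1ccc(S(=O)(=O)N2CCc3cccc(-c4cccc(F)c4)c32)cc1`) is still unmeasured. It carries 3-fluorophenyl in place of 4-(dimethylamino)phenyl on an aromatic carbon and so loses the same dimethylamino group that entered in the measured step. Going by the values given here, no measured compound carries fluorine, and a single step is thin support. That step does suggest that compound 2 owes part of its higher number to what sits on this aromatic ring, so a move toward a lower number seems likely, though probably a smaller one than the measured step. The expected change is a 2.7-fold lower number from compound 2 to compound 3 (0.43 log units; beyond the scatter) in size. In this assay the estimated value for compound 3 is 200 nM (expected range 60 nM to 650 nM).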

Compound 3, half-maximal inhibitory concentration: 98.5 nM
Compound 3: the middle estimate sits 2.0-fold (0.31 log units) above what was measured; the range from low to high includes it.
By their numbers in this assay, from the lowest: compounds 1 and 3 (each within the scatter of the next); then compound 2.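

In this assay there is a 5.5-fold lower number from compound 2 to compound 3 (0.74 log units; beyond the scatter) and this shows that a number well under that of compound 2 at this position does not depend on the 4-nitrophenyl group of compound 1, since 3-fluorophenyl, a different group on the same aromatic carbon, also gives one. With a 1.9-fold higher number from compound 1 to compound 3 (0.27 log units; within the scatter) the 4-nitrophenyl and 3-fluorophenyl groups cannot be told apart in this assay, and compound 2, with its 4-(dimethylamino)phenyl group, now stands as the weakest inhibitor of the three, its steps to both others lying beyond the scatter. Nothing available here explains why 4-(dimethylamino)phenyl stands apart from the other two groups.

Compound 3 differs from compound 1 and compound 2 both in the group on the outer ring and in where that group sits, so the compounds shown cannot separate the two changes, and a 4-fluorophenyl or a 3-(dimethylamino)phenyl group would be needed to do so. From the compounds shown here alone, it also remains open how this position would respond to an unsubstituted phenyl ring, a primary amine or a carboxylic acid on that ring.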